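The source may hold more compounds than are shown below. What is called first, only, known or untested is meant among the compounds shown, and "the series" means these compounds.

Measured so far in a physicochemical assay for solubility, read by HPLC, with a stated time of 24 h; on this read-out higher numbers stand for higher solubility and lower numbers for lower solubility:
- compound 1, `COC(=O)CC1CCN(C[C@H]2CN(c3ccc(-n4cc(-c5ccccn5)cn4)c(F)c3)C(=O)O2)CC1`: 92100 nM
- compound 2, `O=C1CCC(=O)N1C[C@H]1CN(c2ccc(-n3cc(-c4ccccn4)cn3)c(F)c2)C(=O)O1`: 45300 nM
- compound 3, `O=C1O[C@@H](Cn2ccnn2)CN1c1ccc(-n2cc(-c3ccccn3)cn2)c(F)c1`: 247000 nM

Among these three, compound 1 stands second highest: compound 2 sits below it, a 2.0-fold lower number from compound 1 to compound 2 (0.31 log units; beyond the scatter), and compound 3 above it, a 2.7-fold higher number from compound 1 to compound 3 (0.43 log units; beyond the scatter). The unmeasured compound 4, `O=CNC[C@H]1CN(c2ccc(-n3cc(-c4ccccn4)cn3)c(F)c2)C(=O)O1`, differs from compound 1 at the same position where compounds 2 and 3 differ from it: formylamino in place of 4-((methoxycarbonyl)methyl)piperidin-1-yl on a saturated chain carbon bound to a saturated ring carbon. The two measured steps from compound 1 change that group in both directions, and neither involves a formylamino group, so they give only a loose guide. Both steps are modest in size, and the small, ring-free group entering resembles the step towards compound 3 more than that towards compound 2. A modest rise from compound 1 to compound 4 is therefore expected, a 1.6-fold higher number from compound 1 to compound 4 (0.21 log units; within the scatter), so the estimated value of compound 4 in this assay is 150000 nM, with a range from 60000 nM to 400000 nM.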

Compound 4, solubility: 217000 nM
Estimate against measurement, compound 4: 1.4-fold (0.16 log units) below, within the range that was stated.
By their numbers in this assay, from the lowest: compound 2; then compound 1; then compounds 4 and 3 (each within the scatter of the next).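

In this assay formylamino on this saturated chain carbon gives a 2.4-fold higher number from compound 1 to compound 4 (0.37 log units; beyond the scatter) and also a 4.8-fold higher number from compound 2 to compound 4 (0.68 log units; beyond the scatter) with no ring in the entering group. Set against 1H-1,2,3-triazol-1-yl it gives a 1.1-fold lower number from compound 3 to compound 4 (0.06 log units; within the scatter) so a ring in this group is not needed to reach that level. Nothing measured here explains these numbers.

The compounds shown leave open whether the amide hydrogen of formylamino matters, since none carries acetylamino or a methylated amide here. As far as these compounds go, what a free amine, a carboxylic acid or a longer chain would give at this place also stays open.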